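Boc-pyrrolidinyl amide replacing chlorobenzoyl on the shared core

A few compounds are considered here, and "the series" means these few. Any claim that something is new, unique, unknown or untested is made for them only; others in the source may bear on it.

Measured so far:
- compound 1 `O=C(c1ccc(Cl)cc1)N1CCC(NS(=O)(=O)c2cc(S(=O)(=O)c3ccccc3)ccc2C(F)(F)F)CC1` — 1800 nM
- compound 2 `CC(C)(C)OC(=O)N1CCC(C(=O)N2CCC(NS(=O)(=O)c3cc(S(=O)(=O)c4ccccc4)ccc3C(F)(F)F)CC2)CC1` — 420 nM
- compound 3 `CC(C)(C)OC(=O)N1CCC(CC(=O)N2CCC(NS(=O)(=O)c3cc(S(=O)(=O)c4ccccc4)ccc3C(F)(F)F)CC2)CC1` — 400 nM

In an assay on U2OS cells for inhibition of secreted frizzled-related protein 1 (Homo sapiens), read by a luciferase reporter, with a stated time of 18 h (on this read-out lower numbers stand for an effect already at smaller amounts and higher numbers for an effect only at larger amounts of compound), compound 1 gives 1800 nM, the highest of the three numbers. Compound 2 gives 420 nM and compound 3 gives 400 nM; both of these numbers lie clearly below that of compound 1, while the numbers of compound 2 and compound 3 lie together.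

Compound 4 `CC(C)(C)OC(=O)N1CC[C@@H](C(=O)N2CCC(NS(=O)(=O)c3cc(S(=O)(=O)c4ccccc4)ccc3C(F)(F)F)CC2)C1` has not been measured. Against compound 1 the change is 1-(tert-butoxycarbonyl)pyrrolidin-3-yl in place of 4-chlorophenyl on a carbonyl carbon. Both measured compounds that carry a tert-butoxycarbonyl-bearing saturated ring on that carbonyl carbon, compound 2 and compound 3, give numbers well below compound 1 in this assay, so a step in the same direction is expected here as well, beyond the scatter and of about the size seen for those two.

For compound 4 the expected step from compound 1 is a 3.6-fold lower number from compound 1 to compound 4 (0.56 log units; beyond the scatter). The estimate for compound 4 in this assay is 500 nM, within a range of 200 nM to 1200 nM.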

Compound 4, half-maximal effective concentration: 80 nM
Compound 4: the middle estimate sits 6.3-fold (0.80 log units) above what was measured; the measured number lies below the stated range.
By their numbers in this assay, from the lowest: compound 4; then compounds 3 and 2 (each within the scatter of the next); then compound 1.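

In this assay the exchange of 4-chlorophenyl for 1-(tert-butoxycarbonyl)pyrrolidin-3-yl on the carbonyl carbon gives a 23-fold lower number from compound 1 to compound 4 (1.35 log units; beyond the scatter) and shows that this position can carry a non-aromatic ring with a defined stereocentre and still reach a much lower number. Compound 4 at 80 nM also lies below compound 2 at 420 nM and compound 3 at 400 nM in this series, so the two earlier values, which lie together, are not the lowest numbers reached with tert-butoxycarbonyl-bearing saturated rings at this place. Nothing measured here accounts for the size of the step.

Still open, as far as these compounds go, is how much depends on the tert-butoxycarbonyl group, which a free secondary amine or an acetyl group on the pyrrolidine nitrogen would test. The opposite configuration at the stereocentre also remains unresolved.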